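Replacing 4-methylphenyl with naphthalen-2-yl in compound 1

The compounds below may be only part of what the source reports. "The series", "measured", "known", "first", "only" and "open" are said of these compounds alone.

Measured compounds:
compound 1 `Cc1ccc(Cn2cc(CSc3nnc(-c4ccccc4)c(-c4ccccc4)n3)nn2)cc1` — 34800 nM
compound 2 `c1ccc(Cn2cc(Cc3nnc(-c4ccccc4)c(-c4ccccc4)n3)nn2)cc1` — 11400 nM
compound 3 `COc1ccc(C(=O)/C=C/c2ccc(-n3cc(CSc4nnc(-c5ccccc5)c(-c5ccccc5)n4)nn3)cc2)cc1` — 36700 nM

Three compounds sharing a common core were tested in a functional assay on MGC-803 cells (Homo sapiens) for antiproliferative activity, read by MTT assay, with a stated time of 48 h; on this read-out lower numbers stand for stronger inhibition and higher numbers for weaker inhibition. Compound 1 gives 34800 nM, the second highest of the three numbers. Its nearest neighbour is compound 3, whose value of 36700 nM lies within the scatter of compound 1. Compound 2, at 11400 nM, stands furthest from compound 1 and beyond the scatter, so among these three it shows the strongest inhibition.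

Compound 4 `c1ccc(-c2nnc(SCc3cn(Cc4ccc5ccccc5c4)nn3)nc2-c2ccccc2)cc1` is not yet measured in this assay. It differs from compound 1 by naphthalen-2-yl in place of 4-methylphenyl on a saturated chain carbon bound to an aromatic nitrogen. Among the measured compounds shown here, no pair of measured compounds shows this change, so there is no measured step to lean on. With only the values of compounds 1, 2 and 3 available, the step of a 1.4-fold lower number from compound 1 to compound 4 (0.14 log units; within the scatter) is expected to be modest, leaning toward a lower number but not clearly beyond the scatter. Compound 4 is therefore expected to give 25000 nM, within a range from 10000 nM to 60000 nM.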

Compound 4, half-maximal inhibitory concentration: > 100000 nM
Compound 4: no number, only a limit; the forecaster's own chance of this, stated with the estimate: 15%; middle value at least 4.0-fold (0.60 log units) away from the limit.
By their numbers in this assay, from the lowest: compound 2; then compounds 1 and 3 (each within the scatter of the next). At a limit, above all of these: compound 4.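

In this assay compound 4 gives > 100000 nM, which is a limit of the assay and not a number: the limit of > 100000 nM in this assay, at which 1 of the 4 values shown sits. Naphthalen-2-yl in place of 4-methylphenyl on a saturated chain carbon bound to an aromatic nitrogen gives an at least 2.8-fold higher number from compound 1 to compound 4 (0.45 log units; beyond the scatter). This is the first measured step among these compounds, and it shows that inhibition at this position depends on the group carried there, with the larger aromatic group going towards weaker inhibition.

With this single change at this place, no trend across groups can be read. As far as these compounds go, what an amine or a carboxylic acid in place of 4-methylphenyl would give stays open, as does whether any group there can bring a number lower than that of compound 1.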